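Flipping one ring stereocentre in a cyclopentanol pyridine series

This account rests on a few compounds, and the source may have more. Where it says the series, first, only, none or still open, it means among the compounds named here.

Measured compounds:
Compound 1, `OC(c1ccccn1)C1(c2ccc(Cl)c(Cl)c2)COC1`: 7370 nM
Compound 2, `O[C@]1(c2ccccn2)CC[C@@H](c2ccc(C(F)(F)F)cc2)C1`: 130 nM

Of the compounds shown here, two have been measured in an assay on HEK293 cells for antagonist activity at transient receptor potential cation channel subfamily V member 3 (Homo sapiens), read by FLIPR and calcium flux; on this read-out higher numbers stand for weaker inhibition and lower numbers for stronger inhibition. Compound 1, `OC(c1ccccn1)C1(c2ccc(Cl)c(Cl)c2)COC1`, gives 7370 nM. Compound 2, `O[C@]1(c2ccccn2)CC[C@@H](c2ccc(C(F)(F)F)cc2)C1`, gives 130 nM, the lowest of the two numbers; the gap to compound 1 lies well beyond the scatter. Among the compounds with values here, no pair differing in a single place has been measured, so no step size is known from the data.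

Compound 3, `O[C@]1(c2ccccn2)CC[C@H](c2ccc(C(F)(F)F)cc2)C1`, is the compound still to be measured. Its change from compound 2 is this: the two compounds have the same atoms and bonds and differ only in configuration as drawn: 1 of 2 stereo elements differ; a stereocentre at a saturated ring carbon is drawn R in compound 2 and S in compound 3. Such a change at a ring stereocentre often moves the number noticeably, and the direction cannot be read from the two measured compounds. The expected step from compound 2 to compound 3 in this assay is a 6.2-fold higher number from compound 2 to compound 3 (0.79 log units; beyond the scatter), toward weaker inhibition. Compound 3 is therefore estimated at 800 nM, with a range from 150 nM to 5000 nM.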

Compound 3, antagonist equilibrium constant: 540 nM
Beside the measured number, compound 3's estimate is 1.5-fold (0.17 log units) above it; low and high end bracket the measured number.
By their numbers in this assay, from the lowest: compound 2; then compound 3; then compound 1.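

In this assay, within the data shown here, this pair isolates a single place for the first time, showing that the configuration at this saturated ring carbon matters on its own: the result is a 4.2-fold higher number from compound 2 to compound 3 (0.62 log units; beyond the scatter). Compounds 1 and 2 differ in more than one place, so their gap could not be assigned to any single change. The R drawing goes with the stronger inhibition here, and the shift can be assigned to this stereocentre alone because of one fact: the fact that compounds 2 and 3 differ only in the configuration as drawn

The compounds shown leave open what a change at the second stereo element, drawn the same in compound 2 and compound 3, would do. They also do not tell whether the preference for R would persist if a nitrile replaced the trifluoromethyl group.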